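From Chloro to Fluoro: Estimating Compound 3

The source may report more compounds than this note shows. Statements on the series, on what has been measured and on what is new or still open speak of the compounds shown alone.

Measured so far, in a physicochemical assay for lipophilicity, read by HPLC; on this read-out lower numbers stand for lower lipophilicity and higher numbers for higher lipophilicity:
Compound 1, `Cc1ccsc1C(=CCCN(C)C(CCO)C(=O)NCc1ccccc1)c1sccc1C`, gives 5.71.
Compound 2, `Cc1ccsc1C(=CCCN(C)C(CO)C(=O)NCc1ccc(Cl)cc1)c1sccc1C`, gives 6.47.

Compound 2 stands highest of the two numbers in this assay; its nearest neighbour is compound 1, whose number is lower by a gap that lies beyond the scatter. Going by the values given here, compound 1 and compound 2 differ in more than one place, so no single step between them can be read, and the two values show only where each stands.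

Compound 3, `Cc1ccsc1C(=CCCN(C)C(CO)C(=O)NCc1ccc(F)cc1)c1sccc1C`, has not yet been measured. Relative to compound 2 it carries fluoro in place of chloro on an aromatic carbon. Among the compounds with values here, no measured step of this kind is in hand, so the expectation rests on the change alone: a modest decrease in this assay is expected, probably beyond the scatter but not large. Compound 3 is therefore estimated at 5.95, within a range from 5.55 to 6.35. That estimate means an expected step of a number 0.52 log units lower from compound 2 to compound 3 (beyond the scatter).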

Compound 3, partition coefficient: 6.45
Estimate against measurement, compound 3: 0.50 log units below; the measured number lies above the stated range.
By their numbers in this assay, from the lowest: compound 1; then compounds 3 and 2 (each within the scatter of the next).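

In this assay the exchange of chloro for fluoro on an aromatic carbon of the six-membered ring, para to a large group, comes to a number 0.02 log units lower from compound 2 to compound 3 (within the scatter) and so the 4-chlorobenzyl and 4-fluorobenzyl compounds cannot be told apart on this read-out. Going by these compounds alone, this is the only single-place step in hand: compound 1 and compound 2 differ in more than one place, so their values alone could not show how this position answers to an exchange of one halogen for the other. Nothing in the available evidence bears on why the two halogens read alike.

The compounds shown leave open whether this position would respond to a group of another kind, such as a methoxy, an amine or a carboxylic acid. They also leave open how the gap between compound 1 and compound 2 divides among the places in which those two differ.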